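Swapping a methyl for a phenylethynyl group on a pyridine amide

This account rests on a few compounds, and the source may have more. Where it says the series, first, only, none or still open, it means among the compounds named here.

Measured compounds:
compound 1 `Cc1ccccc1C(=O)Nc1cc(Cl)ccn1`: 128 uL/min
compound 2 `Cc1ccccc1C(=O)Nc1cc(C#N)ccn1`: 82 uL/min
compound 3 `Cc1ccnc(NC(=O)c2ccccc2C)c1`: 129 uL/min

In an ADME assay (liver) for metabolic stability, with Liver microsome (Homo sapiens) as the target, read by LC-MS, using microsomes, with a stated time of 60 min, tested at 1 uM (a higher number here means faster removal of the compound, a lower number slower removal), compound 3 gives 129 uL/min, the highest of the three numbers, though its steps to the other two fall within the scatter: a 1.6-fold higher number from compound 2 to compound 3 (0.20 log units; within the scatter) and a 1.0-fold higher number from compound 1 to compound 3 (0.00 log units; within the scatter), so all three compounds are indistinguishable in this assay.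

Compound 4 `Cc1ccccc1C(=O)Nc1cc(C#Cc2ccccc2)ccn1` has not been measured. Compared with compound 3 it differs in one place: 2-phenylethynyl in place of methyl on an aromatic carbon. The entering group sits on an aromatic carbon of a six-membered aromatic ring with 1 nitrogen, opposite the ring nitrogen.

The measured steps are all exchanges of one small group for another at this same position: a 1.6-fold lower number from compound 1 to compound 2 (0.19 log units; within the scatter), a 1.0-fold higher number from compound 1 to compound 3 (0.00 log units; within the scatter) and a 1.6-fold higher number from compound 2 to compound 3 (0.20 log units; within the scatter). None of them moved the number beyond the scatter, and none involves a group as large as 2-phenylethynyl or one carrying an extra ring. The data therefore give no guide in either direction, and the expected step of a 1.2-fold higher number from compound 3 to compound 4 (0.07 log units; within the scatter) is taken as no change beyond the scatter, with a wide range to reflect the unknown. Compound 4 is estimated at 150 uL/min, between 60 uL/min and 380 uL/min.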

Compound 4, intrinsic clearance in a liver preparation (reported as CLH), per the amount of preparation that the assay uses in the Liver microsome assay: 27 uL/min
The estimate for compound 4 lay 5.6-fold (0.74 log units) above the measured number; measured number outside the range, below it.
By their numbers in the Liver microsome assay, from the lowest: compound 4; then compounds 2, 1 and 3 (each within the scatter of the next).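

In the Liver microsome assay, the small groups at this position stayed within the scatter of each other, but the 2-phenylethynyl group brings a clear fall against all three: a 4.8-fold lower number from compound 3 to compound 4 (0.68 log units; beyond the scatter), a 3.0-fold lower number from compound 2 to compound 4 (0.48 log units; beyond the scatter) and a 4.7-fold lower number from compound 1 to compound 4 (0.68 log units; beyond the scatter). The position opposite the ring nitrogen can therefore change the rate of removal, and the first sign of this comes with a group that adds a carbon-only aromatic ring and a triple bond. In a physicochemical assay for lipophilicity, read by HPLC, at pH 7.4 (on this read-out higher numbers stand for higher lipophilicity and lower numbers for lower lipophilicity), compound 3 gives 2.8 and compound 4 gives 4.7, so the slower removal arrives together with a marked rise in lipophilicity, a link that rests on this single pair: the measured distribution coefficient of compound 3, 2.8, and of compound 4, 4.7, a number 1.90 log units higher (beyond the scatter)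

The compounds shown do not separate the contribution of the triple bond from that of the added ring, and a plain ethynyl group or a phenyl group set directly on the ring would be needed to pull the two apart. They also leave open whether the lower number in the Liver microsome assay would survive if an amine or a carboxylic acid were carried on the end of the 2-phenylethynyl group.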